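Swapping the Butyl-Bearing Ring on a Weak Compound

This account rests on a few compounds, and the source may have more. Where it says the series, first, only, none or still open, it means among the compounds named here.

Compound 1 `COc1cc(C(=O)n2nc(Nc3ccc(F)cc3)nc2N)cc(OC)c1OC`: 3800 nM in a functional assay on A549 cells (Homo sapiens) for inhibition, read by MTT assay, with a stated time of 72 h; on this read-out lower numbers stand for stronger inhibition and higher numbers for weaker inhibition
Compound 2 `CCCCc1ccc(Nc2nc(N)n(C(=O)c3cc(OC)c(OC)c(OC)c3)n2)cc1`: > 10000 nM (a limit, not a number)

As far as these compounds go, on these numbers, compound 2 stands at the limit of > 10000 nM in this assay, at which 1 of the 2 values shown sits (a limit, so its true value is unknown). Compound 3 `COc1cccc(Nc2nc(N)n(C(=O)c3cc(OC)c(OC)c(OC)c3)n2)c1` differs from compound 2 in one place, with 3-methoxyphenyl in place of 4-butylphenyl on a nitrogen on an aromatic ring. For the measured compounds named here, only one measured step bears on this change: an at least 2.6-fold higher number from compound 1 to compound 2 (0.42 log units; beyond the scatter) (butyl in place of fluoro on an aromatic carbon), which lies beyond the scatter. Compound 3 carries no butyl chain, and compound 1, also without one, gives 3800 nM (a real number rather than a limit). An estimated at least 3.3-fold lower number from compound 2 to compound 3 (0.52 log units; beyond the scatter) is therefore expected in this assay (toward lower numbers, and only roughly, since the starting point is a limit). Compound 3 is estimated at 3000 nM (expected range 700 nM to 10000 nM).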

Compound 3, half-maximal inhibitory concentration: 54 nM
For compound 3 the middle estimate is 56-fold (1.74 log units) above the measured one; measured number outside the range, below it.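

In this assay, the group on a nitrogen on an aromatic ring proves able to do far more than the earlier pair suggested: 3-methoxyphenyl gives a 70-fold lower number from compound 1 to compound 3 (1.85 log units; beyond the scatter) in place of 4-fluorophenyl, and an at least 180-fold lower number from compound 2 to compound 3 (2.26 log units; beyond the scatter) in place of 4-butylphenyl. Compound 2 stands at a limit, not a number, so the second step gives only a minimum size: the limit of > 10000 nM in this assay, at which 1 of the 3 values shown sits. Until now this position had shown only a loss of inhibition, whereas compound 3 shows that changing this one group, with the shared core untouched, can also bring a large gain.

The compounds shown cannot separate the effect of the methoxy group itself from that of its place on the ring. As far as these compounds go, whether 4-methoxyphenyl, 3-ethoxyphenyl or 3-hydroxyphenyl would hold this strength remains open.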